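The source may hold more compounds than are shown below. What is called first, only, known or untested is meant among the compounds shown, and "the series" means these compounds.

Measured so far, each value being a limit of the assay:
Compound 1 `Nc1ccccc1NC(=O)c1ccc(NCC(=O)Nc2cccc([N+](=O)[O-])c2)cc1`: > 100000 nM
Compound 2 `Nc1ccccc1NC(=O)CCCNCC(=O)Nc1ccccc1Cl`: > 100000 nM
Compound 3 `COc1ccc(NC(=O)CNCCCC(=O)Nc2ccccc2N)cc1`: > 100000 nM

In a functional assay on HCT-116 cells (Homo sapiens) for inhibition, read by MTT assay, with a stated time of 2 days (on this read-out higher numbers stand for lower toxicity in this test and lower numbers for higher toxicity in this test), compound 1 gives > 100000 nM, which is a limit and not a number. The other two compounds stand in the same way: the limit of > 100000 nM in this assay, at which 3 of the 3 values shown sit. Compound 4 `Nc1ccccc1NC(=O)c1ccc(NCC(=O)Nc2ccc(Cl)cc2)cc1` differs from compound 1 in one place: 4-chlorophenyl in place of 3-nitrophenyl on an amide-type nitrogen. Here 4-chlorophenyl stands in place of 3-nitrophenyl on an amide-type nitrogen. Within the data shown here, the only measured step, also on an amide-type nitrogen, is a step that the two limits leave unreadable from compound 2 to compound 3, so it offers no size to carry over. No step beyond the scatter is therefore expected in this assay, and no direction. The expected outcome is a number no higher from compound 1 to compound 4 (the limit leaves the size open), which is an estimate. For compound 4 the estimated value is 100000 nM, with an expected range of 30000 nM to 200000 nM.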

Compound 4, concentration lethal to 50% of the cells: > 100000 nM
Compound 4 gave a limit, no number; the forecaster's own chance of this, stated with the estimate: 70%; the middle value sits exactly at the limit.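

Compound 1 and compound 4 each give a limit and not a number in this assay, so no step between them can be read: the limit of > 100000 nM in this assay, at which 4 of the 4 values shown sit.

The compounds shown leave open whether swapping the group on the amide-type nitrogen changes anything in this assay.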